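A few compounds are considered here, and "the series" means these few. Any claim that something is new, unique, unknown or untested is made for them only; others in the source may bear on it.

Compound 1 `CS(=O)(=O)Nc1ccc(-n2cc(COc3ccccc3Cl)nn2)cc1Oc1ccccc1`: 38600 nM
Compound 2 `CS(=O)(=O)Nc1ccc(-n2cc(-c3ccccc3)nn2)cc1Oc1ccccc1`: 21900 nM

Among the measured compounds shown here, in a functional assay on HeLa cells (Homo sapiens) for inhibition, read by MTT assay, with a stated time of 48 h (on this read-out higher numbers stand for weaker inhibition and lower numbers for stronger inhibition), compound 2 gives 21900 nM, and the only other measured compound, compound 1, lies within the scatter of it. Compound 3 `Cc1ccc(OCc2cn(-c3ccc(NS(C)(=O)=O)c(Oc4ccccc4)c3)nn2)cc1` differs from compound 2 as follows: (4-methylphenoxy)methyl in place of phenyl on an aromatic carbon. In words, (4-methylphenoxy)methyl stands in place of phenyl on an aromatic carbon. For the measured compounds named here, one measured step bears on this change: a 1.8-fold lower number from compound 1 to compound 2 (0.25 log units; within the scatter). It exchanged (2-chlorophenoxy)methyl for phenyl and stayed within the scatter, so no step beyond the scatter is expected in this assay. The expected step is a 1.5-fold higher number from compound 2 to compound 3 (0.18 log units; within the scatter). For compound 3, the estimated value is 33000 nM, with an expected range of 14000 nM to 80000 nM.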

Compound 3, half-maximal inhibitory concentration: 15800 nM
Estimate against measurement, compound 3: 2.1-fold (0.32 log units) above, and the stated range covers the measured number.
By their numbers in this assay, from the lowest: compounds 3, 2 and 1 (each within the scatter of the next, the first and the last beyond it).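

In this assay, swapping phenyl for the larger (4-methylphenoxy)methyl on the aromatic carbon gives a 1.4-fold lower number from compound 2 to compound 3 (0.14 log units; within the scatter), so this position accepts the extra oxygen-linked group with no change beyond the scatter. Within the oxygen-linked series, 4-methylphenyl in place of 2-chlorophenyl gives a 2.4-fold lower number from compound 1 to compound 3 (0.39 log units; beyond the scatter), the first step here to pass the scatter, though only modestly. Nothing available explains either result. That swap alters both the substituent and its place on the ring, so it remains unclear which matters. Going by these compounds, how a carboxylic acid or an aminomethyl group would behave on the same aromatic carbon also remains open.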